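The source may report more compounds than this note shows. Statements on the series, on what has been measured and on what is new or still open speak of the compounds shown alone.

Of the compounds shown here, three sharing one core have been measured in an ADME assay on microsomes from liver (Homo sapiens) for metabolic stability, read by LC-MS, tested at 1 mM; a lower number here means that the compound disappears faster, a higher number that the compound lasts longer. Compound 1 `N#Cc1ccc(F)cc1Cn1c(N2CCC[C@@H](N)C2)nc2cc[nH]c2c1=O` gives 3.33 h. Compound 2 `N#Cc1ccc(F)cc1Cn1c(N2CCC[C@@H](N)C2)nc2c(F)c[nH]c2c1=O` gives 1.64 h. Compound 3 `CC(C)S(=O)(=O)c1ccc(-c2c[nH]c3c(=O)n(Cc4cc(F)ccc4C#N)c(N4CCC[C@@H](N)C4)nc23)cc1` gives 0.722 h. Compound 2 thus stands second highest of the three: compound 1 sits above it by a 2.0-fold lower number from compound 1 to compound 2 (0.31 log units; beyond the scatter), and compound 3 sits below it by a 2.3-fold lower number from compound 2 to compound 3 (0.36 log units; beyond the scatter).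

Compound 4 `CS(=O)(=O)c1ccc(-c2c[nH]c3c(=O)n(Cc4cc(F)ccc4C#N)c(N4CCC[C@@H](N)C4)nc23)cc1F` has not yet been measured in this assay. It differs from compound 2 in one place: 3-fluoro-4-(methylsulfonyl)phenyl in place of fluoro on an aromatic carbon. Among the measured compounds shown here, the closest precedent is the step from compound 2 to compound 3, where the 4-(isopropylsulfonyl)phenyl group likewise replaced the fluoro and gave a 2.3-fold lower number from compound 2 to compound 3 (0.36 log units; beyond the scatter); from compound 1 the same group gave a 4.6-fold lower number from compound 1 to compound 3 (0.66 log units; beyond the scatter). Both steps lowered the number beyond the scatter. A step in the same direction and of similar size is therefore expected in this assay, a 2.1-fold lower number from compound 2 to compound 4 (0.31 log units; beyond the scatter). Compound 4 is estimated at 0.8 h, with a range from 0.4 h to 1.6 h.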

Compound 4, half-life: > 3.33 h
Compound 4: no number, only a limit (the forecaster's own chance of this, stated with the estimate: 5%); middle value at least 4.1-fold (0.61 log units) away from the limit.
By their numbers in this assay, from the lowest: compound 3; then compound 2; then compound 1.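

In this assay compound 4 gives > 3.33 h, which is a limit of the assay and not a number. Placing an aromatic ring on this carbon therefore need not shorten the half-life: 3-fluoro-4-(methylsulfonyl)phenyl in place of fluoro gives an at least 2.0-fold higher number from compound 2 to compound 4 (0.30 log units; that floor lies within the scatter). What that ring carries matters, as 3-fluoro-4-(methylsulfonyl)phenyl in place of 4-(isopropylsulfonyl)phenyl gives an at least 4.6-fold higher number from compound 3 to compound 4 (0.66 log units; beyond the scatter).

3-Fluoro-4-(methylsulfonyl)phenyl in place of hydrogen gives a number no lower from compound 1 to compound 4 (the limit leaves the size open), a step whose size cannot be read, and the true size of the half-life of compound 4 stays unknown. Going by these compounds, compounds 3 and 4 differ in both the sulfonyl substituent and the ring fluorine, so it remains open which of the two counts, and how 4-(methylsulfonyl)phenyl without that fluorine, or a phenyl ring carrying an amine or a carboxylic acid, would behave here.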